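Cyclopropyl in Place of Methyl: From Compound 2 to Compound 3

This account rests on a few compounds, and the source may have more. Where it says the series, first, only, none or still open, it means among the compounds named here.

Compound 1 `O=c1c2[nH]c(Cc3cccs3)nc2n(Cc2ccco2)c(=O)n1CC1CC1` in an assay on cell membranes for displacement of a labelled ligand from adenosine receptor A1 (Rattus norvegicus) (a higher number here means a weaker inhibitor, a lower number a stronger inhibitor), gives 347 nM.
Compound 2 `CCn1c(=O)c2c(nc(Cc3cccs3)n2C)n(Cc2ccco2)c1=O` in this assay gives 102 nM.

Compound 2 holds the lower of the two values, and its distance from compound 1 lies beyond the scatter. Compound 3 `Cn1c(Cc2cccs2)nc2c1c(=O)n(CC1CC1)c(=O)n2Cc1ccco1` has not been measured. It differs from compound 2 in one place: cyclopropyl in place of methyl on a saturated chain carbon bound to an aromatic nitrogen. For the measured compounds named here, no measured pair shows this change alone, so its size is unknown. A small shift toward a higher number is expected, a 1.5-fold higher number from compound 2 to compound 3 (0.17 log units; within the scatter), staying within the scatter. Compound 3 is therefore estimated at 150 nM, with a range from 60 nM to 400 nM.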

Compound 3, inhibition constant: 100 nM
Compound 3: the middle estimate sits 1.5-fold (0.18 log units) above what was measured, within the range that was stated.
By their numbers in this assay, from the lowest: compounds 3 and 2 (each within the scatter of the next); then compound 1.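

At this position on a saturated chain carbon bound to an aromatic nitrogen, cyclopropyl in place of methyl, which also reads as ethyl to cyclopropylmethyl, leaves the inhibition in this assay unchanged within the scatter (a 1.0-fold lower number from compound 2 to compound 3 (0.01 log units; within the scatter)). Methyl in place of hydrogen on an aromatic nitrogen, seen alone for the first time, gives a step beyond the scatter (a 3.5-fold lower number from compound 1 to compound 3 (0.54 log units; beyond the scatter)). Nothing measured here accounts for either result. The compounds shown leave open whether a longer chain, such as butyl, or an amine at this position would also leave the value unchanged.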